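The source may hold more compounds than are shown below. What is called first, only, known or untested is meant among the compounds shown, and "the series" means these compounds.

Measured compounds:
Compound 1 `CCNC(=O)c1noc(-c2cc(C(C)C)c(O)cc2O)c1-c1cc(COCC(=O)O)no1` – "not determined" (no result reported)
Compound 2 `CCCNCc1cc(-c2c(C(=O)NCC)noc2-c2cc(C(C)C)c(O)cc2O)on1` – 117 nM

Going by the values given here, the series so far offers little to compare. Among the compounds with values here, in a functional assay on HCT-116 cells (Homo sapiens) for inhibition (on this read-out lower numbers stand for stronger inhibition and higher numbers for weaker inhibition), compound 2 gives 117 nM, and this is the only number available, so it cannot yet be ranked against anything. Within the data shown here, compound 1 differs from it in the group carried on the shared core, but has no result reported, which leaves no measured step to serve as a guide.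

The next compound to be tested is compound 3 `C=CNCc1cc(-c2c(C(=O)NCC)noc2-c2cc(C(C)C)c(O)cc2O)on1`, which keeps the core of compound 2 and carries vinyl in place of propyl on an amine nitrogen. Among the measured compounds shown here, the data hold no example of this change or of any other change at this place. With compound 2 at 117 nM as the sole reference, a small step in this assay is expected, perhaps slightly towards weaker inhibition, and probably none beyond the usual scatter. The expected change is a 1.1-fold higher number from compound 2 to compound 3 (0.05 log units; within the scatter). For compound 3 the estimated value is 130 nM, with an expected range from 45 nM to 380 nM.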

Compound 3, half-maximal inhibitory concentration: 121 nM
Compound 3: middle estimate off by 1.1-fold (0.03 log units), on the high side, within the range that was stated.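

In this assay, going by these compounds alone, vinyl in place of propyl on an amine nitrogen gives a 1.0-fold higher number from compound 2 to compound 3 (0.01 log units; within the scatter), the first measured step at this place. For this pair, the shorter vinyl chain with its double bond outside aromatic rings and the saturated propyl chain cannot be told apart on this read-out, so swapping one for the other on a nitrogen whose other neighbour is a saturated chain carbon leaves the inhibition number within the scatter. No measurement at hand explains why the two chains read alike.

The compounds shown leave open whether this indifference holds only for these two small chains or extends to other groups on the same nitrogen, such as a longer chain like butyl or hexyl, a ring such as cyclopropyl or benzyl, or a hydroxyethyl chain. They also leave open what happens with a bare primary amine, or with a tertiary amine carrying a second methyl or ethyl group on that nitrogen, where a single pair offers no guide.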